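The compounds below may be only part of what the source reports. "The series", "measured", "known", "first", "only" and "open" are said of these compounds alone.

Three compounds of the shared core have been run in an ADME assay on MT4 cells (Homo sapiens) for cytotoxicity, read by MTT assay, with a stated time of 96 h; a lower number here means that less compound is tolerated, a higher number that more compound is tolerated. Compound 1 `Oc1ccc(-c2nc3cc(Cl)c(Cl)cc3[nH]2)cc1` gives 12000 nM in this assay. Compound 3 `COc1ccc(-c2nc3cc(C(F)(F)F)ccc3[nH]2)cc1` gives 2000 nM in this assay. For compound 2 `CC(=O)Nc1ccc(-c2nc3cc([N+](=O)[O-])ccc3[nH]2)cc1` this assay reports only a limit, > 100000 nM. Among the measured compounds shown here, compound 2 therefore stands at the limit of > 100000 nM in this assay, at which 1 of the 3 values shown sits, and is the one compound of the three without a number; its distance to compound 1 and to compound 3 is known only as a bound. Compound 4 `CC(=O)Nc1ccc(-c2nc3ccccc3[nH]2)cc1` has not been measured in this assay. It differs from compound 2 in one place: hydrogen in place of nitro on an aromatic carbon. For the measured compounds named here, no step between measured compounds is available, and no measured pair shows this change. The expected step from compound 2 to compound 4 in this assay is small, none beyond the scatter, with a number close to the limit at which compound 2 sits. Compound 4 is estimated at 80000 nM, with a range of 25000 nM to 200000 nM. The step meant by this estimate, an at least 1.2-fold lower number from compound 2 to compound 4 (0.09 log units; that floor lies within the scatter), is expected to lie within the scatter.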

Compound 4, half-maximal cytotoxic concentration: 100000 nM
For compound 4 the middle estimate is 1.3-fold (0.10 log units) below the measured one, and the stated range covers the measured number.
By their numbers in this assay, from the lowest: compound 3; then compound 1; then compound 4.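

In this assay, among the compounds shown here, compound 4, with hydrogen in place of nitro on an aromatic carbon, gives a true number of 100000 nM, the first number for this substitution pattern on the acetamide side of the series. Compound 2 carries only a limit, > 100000 nM. The change therefore shows a number no higher from compound 2 to compound 4 (the limit leaves the size open), and its size cannot be read because one end of the step is a limit: the limit of > 100000 nM in this assay, at which 1 of the 4 values shown sits.

From the compounds shown here alone, whether an amine or a carboxylic acid on this aromatic carbon would bring the number down within this assay stays open.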